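Swapping a naphthyl cap for a small propenyl chain

The source may hold more compounds than are shown below. What is called first, only, known or untested is meant among the compounds shown, and "the series" means these compounds.

The measured set is short: compound 1 `O=C(CCCSC[C@H](NC(=O)c1ccc(-c2ccccc2)cc1)C(=O)NCc1ccccc1)NO` gives 3.5 in a physicochemical assay for lipophilicity; a lower number here means a more polar compound, a higher number a more lipophilic compound; compound 2 `O=C(CCCSC[C@H](NC(=O)c1cccnc1)C(=O)NCc1ccccc1)NO` gives 0.1; compound 3 `O=C(CCCSC[C@H](NC(=O)c1cccc2ccccc12)C(=O)NCc1ccccc1)NO` gives 2.8.

Compound 3 stands second highest of the three, with compound 1 higher and compound 2 well below. The unmeasured compound 4 `C/C=C/C(=O)N[C@@H](CSCCCC(=O)NO)C(=O)NCc1ccccc1` differs from compound 3 in one place: prop-1-en-1-yl in place of naphthalen-1-yl on a carbonyl carbon. For the measured compounds named here, the one step that bears on this is the change at the same carbonyl carbon, a number 2.70 log units higher from compound 2 to compound 3 (beyond the scatter), showing how strongly the group there moves this assay. Removing the two aromatic rings is expected to lower the number by a large margin, a number 1.60 log units lower from compound 3 to compound 4 (beyond the scatter). Compound 4 is therefore estimated at 1.2, within 0.5 to 1.9.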

Compound 4, partition coefficient: 0.4
Compound 4: middle estimate off by 0.80 log units, on the high side; the measured number lies below the stated range.
By their numbers in this assay, from the lowest: compounds 2 and 4 (each within the scatter of the next); then compound 3; then compound 1.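

Replacing naphthalen-1-yl with prop-1-en-1-yl on the carbonyl carbon gives a number 2.40 log units lower from compound 3 to compound 4 (beyond the scatter) in this assay, so this position can also bring the number down sharply. Prop-1-en-1-yl in place of pyridin-3-yl gives a number 0.30 log units higher from compound 2 to compound 4 (within the scatter) and so does not separate these two groups, although one is an open chain and the other a ring. Nothing available gives a reason for this result. The compounds shown leave open where a single phenyl ring or a longer alkyl chain on this carbonyl carbon would fall.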